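A few compounds are considered here, and "the series" means these few. Any claim that something is new, unique, unknown or untested is made for them only; others in the source may bear on it.

Measured compounds:
compound 1, `Cc1ccc2nc(-c3ccc(N)cc3)cn2c1`, > 100000 nM;
compound 2, `Cc1ccc2nc(-c3ccc(NCc4ccccc4)cc3)cn2c1`, > 100000 nM;
compound 3, `Cc1ccn2cc(-c3ccc(NCc4ccccc4)cc3)nc2c1`, "not determined" (no result reported).

The read-out throughout is a functional assay on HepG2 cells (Homo sapiens) for antiproliferative activity, read by MTT assay, with a stated time of 72 h; a higher number here means a weaker inhibitor of growth, a lower number a stronger inhibitor of growth. For compound 1 the value > 100000 nM is a limit of the assay and not a number. For compound 2 the value > 100000 nM is likewise a limit of the assay. For compound 3 no result is reported in this assay. The change from compound 1 to compound 2 is benzyl in place of hydrogen on a nitrogen on an aromatic ring, and its step that the two limits leave unreadable from compound 1 to compound 2 cannot be read, since both ends sit at the limit of > 100000 nM in this assay, at which 2 of the 3 values shown sit.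

Compound 4, `Cc1ccn2cc(-c3ccc(N(Cc4ccccc4)Cc4ccccc4)cc3)nc2c1`, has not been measured in this assay. It differs from compound 3 by benzyl in place of hydrogen on a nitrogen on an aromatic ring. This is the same kind of change as that from compound 1 to compound 2, but around the place the neighbours differ: in compound 1 the nitrogen's other neighbour is an aromatic carbon only, while in compound 3 its other neighbours are an aromatic carbon and a saturated chain carbon. How the core of compound 3 differs from the core of compound 1 is not broken down here.

Among the compounds with values here, since the only two values in this assay both sit at the limit of > 100000 nM in this assay, at which 2 of the 3 values shown sit, and compound 3 has no result at all, there is no measured step on which a size for compound 3 to compound 4 could rest. Compound 4 is therefore expected to show weak growth inhibition, with an estimate of 100000 nM and a range from 30000 nM to 300000 nM, most likely reported again only as a limit.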

Compound 4, concentration for 50% growth inhibition: 18400 nM
For compound 4 the middle estimate is 5.4-fold (0.74 log units) above the measured one, and the stated range ends above it.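

In this assay, within the data shown here, compound 4 gives 18400 nM, while compound 3 stands at "not determined" (no result reported), so no step between compound 3 and compound 4 can be read. The compounds shown leave open what the added benzyl on the nitrogen contributes to growth inhibition on the core of compound 3, and whether it contributes anything on the core of compound 1.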